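The source may hold more compounds than are shown below. What is called first, only, known or untested is meant among the compounds shown, and "the series" means these compounds.

The compounds here were tested in a functional assay on MDA-MB-231 cells (Homo sapiens) for inhibition, read by sulforhodamine B assay, with a stated time of 48 h; a lower number here means a stronger inhibitor, a higher number a weaker inhibitor. Compound 1 `CCOC(=O)CCO/N=C(/c1ccc(OC)c(OC)c1OC)c1cccc2ccccc12` gives 15200 nM in this assay. Compound 2 `CCOC(=O)C(C)C(O)(c1ccc(OC)c(OC)c1OC)c1cccc2ccccc12` is reported only as a limit, > 20000 nM, meaning the assay did not return a number for it; this is the limit of > 20000 nM in this assay, at which 1 of the 3 values shown sits. Compound 3 `COc1ccc(C(c2ccccc2O)c2cccc3ccccc23)c(OC)c1OC` gives 17700 nM in this assay, the higher of the two numbers recorded, though its gap to compound 1 lies within the usual scatter, so the two cannot be told apart.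

Compound 4 `COc1ccc(C(c2ccc(OCC(=O)O)cc2)c2cccc3ccccc23)c(OC)c1OC` has not been measured in this assay. It differs from compound 3 in one place: 4-(carboxymethoxy)phenyl in place of 2-hydroxyphenyl on a saturated chain carbon bound to two aromatic carbons. Among the measured compounds shown here, no step between measured compounds is available that resembles this change, so the expectation rests on the general picture, in which all three measured compounds sit near the top of the range this assay reports.

Against that background, compound 4 is expected to stay in the same weak region, with a step from a 1.1-fold higher number from compound 3 to compound 4 (0.05 log units; within the scatter) that is at most modest and may not rise beyond the scatter. Compound 4 is therefore estimated at 20000 nM in this assay, with a plausible range from 8000 nM to 50000 nM, and a real chance that only a limit is reported.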

Compound 4, half-maximal inhibitory concentration: > 20000 nM
Compound 4 gave a limit, no number; the forecaster's own chance of this, stated with the estimate: 50%; the middle value lies on the limit itself.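

In this assay compound 4 is reported only as a limit, > 20000 nM. The swap of 2-hydroxyphenyl for 4-(carboxymethoxy)phenyl on a saturated chain carbon bound to two aromatic carbons therefore reads as an at least 1.1-fold higher number from compound 3 to compound 4 (0.05 log units; that floor lies within the scatter), and that figure is only a floor, so it shows no gain in inhibition while leaving the true size of the step unknown. This is the first change at this place that can be read from a pair of compounds, and it shows that a larger group carrying a carboxylic acid does not lift this series out of its weak region, with the limit now reached by more of the compounds shown: the limit of > 20000 nM in this assay, at which 2 of the 4 values shown sit.

The compounds shown cannot separate the parts of this change, so the effects of the carboxymethoxy chain and of the different place on the phenyl ring remain unresolved. A pair comparing 2-hydroxyphenyl with 4-hydroxyphenyl would address the place on the ring, and a phenyl ring carrying an amine would test a different kind of group at the same carbon.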